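A few compounds are considered here, and "the series" means these few. Any claim that something is new, unique, unknown or untested is made for them only; others in the source may bear on it.

Working notes on the series, read in a physicochemical assay for metabolic stability, read by HPLC and mass spectrometry, in phosphate buffer, at 37 degrees C, at pH 7.4; on this read-out lower numbers stand for a shorter-lived compound and higher numbers for a longer-lived compound. Here compound 1 `CN(C[C@@H]1[C@H](NC(=O)/C(=N\OC(C)(C)C(=O)O)c2csc(N)n2)C(=O)N1S(=O)(=O)O)C(=O)CN` gives 212 h and compound 3 `CC(C)(O/N=C(\C(=O)N[C@@H]1C(=O)N(S(=O)(=O)O)[C@@H]1Cn1ccnn1)c1csc(N)n1)C(=O)O` gives 257 h, so these two lie within the scatter of each other. Compound 2 `CC(C)(O/N=C(\C(=O)N[C@@H]1C(=O)N(S(=O)(=O)O)[C@@H]1CN1CCC1=O)c1csc(N)n1)C(=O)O` is reported only as a limit, > 1000 h.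

Compound 4 `CC(C)(O/N=C(\C(=O)N[C@@H]1C(=O)N(S(=O)(=O)O)[C@@H]1Cn1cncn1)c1csc(N)n1)C(=O)O` carries 1H-1,2,4-triazol-1-yl in place of 1H-1,2,3-triazol-1-yl on a saturated chain carbon bound to a saturated ring carbon. The two have the same atoms, joined differently.

Two measured steps at this place bear on the change: a 1.2-fold higher number from compound 1 to compound 3 (0.08 log units; within the scatter) and an at least 3.8-fold lower number from compound 2 to compound 3 (0.59 log units; beyond the scatter). The second shows that a change here can move the half-life, but neither step exchanges one triazole for the other. No step beyond the scatter is therefore expected in this assay, with a wide range kept in view of compound 2 and an at least 3.8-fold lower number from compound 2 to compound 3 (0.59 log units; beyond the scatter). The expected step is a 1.1-fold higher number from compound 3 to compound 4 (0.04 log units; within the scatter). The estimated half-life of compound 4 is 280 h, with an expected range of 130 h to 650 h.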

Compound 4, half-life: 233 h
Estimate against measurement, compound 4: 1.2-fold (0.08 log units) above; low and high end bracket the measured number.
By their numbers in this assay, from the lowest: compounds 1, 4 and 3 (each within the scatter of the next). At a limit, above all of these: compound 2.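

In this assay, for the compounds shown here, the first direct exchange of one triazole for the other gives a 1.1-fold lower number from compound 3 to compound 4 (0.04 log units; within the scatter), so the half-life does not tell these two rings apart. Compound 4 also stays level with the open-chain group of compound 1, at a 1.1-fold higher number from compound 1 to compound 4 (0.04 log units; within the scatter), which places compounds 1, 3 and 4 together whichever of these groups sits on the saturated chain carbon. Only 2-oxoazetidin-1-yl stands apart, with an at least 4.2-fold lower number from compound 2 to compound 4 (0.63 log units; beyond the scatter), and the size of that step is a bound rather than a measured gap: the limit of > 1000 h in this assay, at which 1 of the 4 values shown sits.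

As far as these compounds go, how far compound 2 truly lies from the others remains open, as its value is a limit. Also open, from the compounds shown here alone, is whether 2-oxopyrrolidin-1-yl, a plain amine or a carboxylic acid at this place would read with compound 2 or with the triazoles.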